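The compounds below may be only part of what the source reports. "The series", "measured", "known", "first", "only" and "open" are said of these compounds alone.

Among the measured compounds shown here, in a functional assay on MDA-MB-231 cells (Homo sapiens) for antiproliferative activity, read by MTT assay, with a stated time of 72 h (on this read-out higher numbers stand for weaker inhibition and lower numbers for stronger inhibition), only two compounds have numbers so far. For the measured compounds named here, compound 1 (`O=S1(=O)C=Cc2cccc(Nc3ccc(OC(F)(F)F)cc3)c21`) gives 2100 nM, and compound 2 (`O=S1(=O)C=Cc2cccc(Nc3ccc(C(F)(F)F)cc3)c21`) gives 1200 nM, so compound 2 stands within the usual scatter of the one compound it can be compared with. Compound 3 (`O=S1(=O)C=Cc2cccc(Nc3ccc(Cl)cc3)c21`) has not yet been measured. It carries chloro in place of trifluoromethyl on an aromatic carbon, para to a large group: chloro in place of trifluoromethyl on an aromatic carbon. Going by the values given here, only one measured step bears on this change, the exchange of trifluoromethoxy for trifluoromethyl on an aromatic carbon, and it amounted to a 1.8-fold lower number from compound 1 to compound 2 (0.24 log units; within the scatter). Among the compounds with values here, with that as the only guide, no step beyond the scatter is expected in this assay. The estimated change is a 1.3-fold higher number from compound 2 to compound 3 (0.10 log units; within the scatter). For compound 3 the expected value is 1500 nM, with an estimated range from 600 nM to 3500 nM.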

Compound 3, half-maximal inhibitory concentration: 1210 nM
For compound 3 the middle estimate is 1.2-fold (0.09 log units) above the measured one, within the range that was stated.
By their numbers in this assay, from the lowest: compounds 2, 3 and 1 (each within the scatter of the next).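

In this assay, chloro in place of trifluoromethyl on this aromatic carbon, para to a large group, gives a 1.0-fold higher number from compound 2 to compound 3 (0.00 log units; within the scatter), and chloro in place of trifluoromethoxy gives a 1.7-fold lower number from compound 1 to compound 3 (0.24 log units; within the scatter). The earlier pair compared only trifluoromethoxy with trifluoromethyl, whereas these steps show that chloro, with 1 heavy atom, also stays within the scatter of both larger groups, so the three compounds cannot be told apart in this assay. Nothing available explains this absence of a measurable difference.

The compounds shown leave open whether an amine, a carboxylic acid or a longer chain at this same place would give a number beyond the scatter of these three. Among the compounds shown here, they also leave open whether a change elsewhere on the shared core would do so, as every step so far lies within the scatter.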